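Bromophenyl in Place of Difluorophenyl on the Aromatic Nitrogen

This account rests on a few compounds, and the source may have more. Where it says the series, first, only, none or still open, it means among the compounds named here.

For the measured compounds named here, compound 2 `COc1cc2c(Oc3ccc(NC(=O)c4nnn(-c5ccc(F)c(F)c5)c4C(F)(F)F)cc3F)ccnc2cc1OCCCN1CCC(C)CC1` is one of two compounds measured in a functional assay on MKN-45 cells (Homo sapiens) for cytotoxicity, read by MTT assay, with a stated time of 72 h; on this read-out higher numbers stand for weaker inhibition and lower numbers for stronger inhibition. Going by the values given here, in that assay compound 2 gives 50 nM, the lower of the two numbers, with compound 1 `COc1cc2c(Oc3ccc(NC(=O)c4nnn(-c5ccccc5C(F)(F)F)c4C(F)(F)F)cc3F)ccnc2cc1OCCCN1CCC(C)CC1` nearest, which gives 100 nM; the only measured step, a 2.0-fold lower number from compound 1 to compound 2 (0.30 log units; within the scatter), lies within the scatter. Compound 3 `COc1cc2c(Oc3ccc(NC(=O)c4nnn(-c5cccc(Br)c5)c4C(F)(F)F)cc3F)ccnc2cc1OCCCN1CCC(C)CC1` has not yet been measured. It differs from compound 2 in one place: 3-bromophenyl in place of 3,4-difluorophenyl on an aromatic nitrogen. Among the compounds with values here, the one measured step, a 2.0-fold lower number from compound 1 to compound 2 (0.30 log units; within the scatter), also exchanged the group on this same aromatic nitrogen and stayed within the scatter, so no step beyond the scatter is expected in this assay for compound 3 either. The estimate for compound 3 is 70 nM, with a range from 25 nM to 200 nM. That estimate corresponds to an expected step of a 1.4-fold higher number from compound 2 to compound 3 (0.15 log units; within the scatter).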

Compound 3, half-maximal inhibitory concentration: 120 nM
Beside the measured number, compound 3's estimate is 1.7-fold (0.23 log units) below it; measured number inside the range.
By their numbers in this assay, from the lowest: compounds 2, 1 and 3 (each within the scatter of the next, the first and the last beyond it).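

In this assay, a change of group on this aromatic nitrogen now gives a 2.4-fold higher number from compound 2 to compound 3 (0.38 log units; beyond the scatter), a modest step beyond the scatter, whereas the earlier exchange at this position stayed within it. The other new comparison, a 1.2-fold higher number from compound 1 to compound 3 (0.08 log units; within the scatter), lies within the scatter, so the 3-bromophenyl and 2-(trifluoromethyl)phenyl groups cannot be ordered here, and compound 2 stands apart from compound 3 only. Nothing shown here accounts for the step.

Since 3-bromophenyl differs from 3,4-difluorophenyl in more than one feature, the compounds leave open whether the step follows from the bromine or from the absence of the two fluorines. They also leave open what a phenyl group carrying an amine or a carboxylic acid, or a cyclohexyl group, would give on this nitrogen.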